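Swapping the aryl substituent on a weakly active chromone core

The compounds below may be only part of what the source reports. "The series", "measured", "known", "first", "only" and "open" are said of these compounds alone.

Compound 2 `CCC1=C(O)c2c(oc(-c3ccc(COC)cc3)cc2=O)C(CC)(CC)C1=O` carries a 4-(methoxymethyl)phenyl group on the shared core. In a functional assay on KB cells (Homo sapiens) for antiproliferative activity, read by sulforhodamine B assay, with a stated time of 3 days (a lower number here means that less compound is needed, a higher number that more compound is needed for the effect), compound 2 reaches only a limit of the assay, > 52.4 uM, not a number. Its closest measured neighbour is compound 1 `CCC1=C(O)c2c(oc(-c3ccc(C(F)(F)F)cc3)cc2=O)C(CC)(CC)C1=O`, and in this assay compound 1 gives 35.7 uM. Going by the values given here, the one measured comparison is therefore an at least 1.4-fold higher number from compound 1 to compound 2 (0.16 log units; that floor lies within the scatter), whose floor lies within the scatter but whose ceiling is unknown; the limit of > 52.4 uM in this assay, at which 1 of the 2 values shown sits, shows where compound 2 sits. Compound 3 `CCC1=C(O)c2c(oc(-c3ccc(OC)c(F)c3)cc2=O)C(CC)(CC)C1=O` differs from compound 2 by 3-fluoro-4-methoxyphenyl in place of 4-(methoxymethyl)phenyl on an aromatic carbon. Among the compounds with values here, no measured step matches this exchange, and the only step known leaves the size of any movement open, so no shift beyond the scatter is expected: the step of an at least 1.1-fold lower number from compound 2 to compound 3 (0.06 log units; that floor lies within the scatter) is the estimate. Compound 3 is accordingly expected to give about 45 uM, between 18 uM and 110 uM, with a fair chance that this assay again reports only a limit.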

Compound 3, concentration for half-maximal effect: 26.7 uM
Compound 3: the middle estimate sits 1.7-fold (0.23 log units) above what was measured, and the stated range covers the measured number.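

In this assay, on these data alone, the exchange at this position gives an at least 1.9-fold lower number from compound 2 to compound 3 (0.29 log units; that floor lies within the scatter); the true size of the move stays unknown, since only its floor can be read. What is new is that a second aryl group on the shared core yields a real number: compound 1 gives 35.7 uM and compound 3 gives 26.7 uM, two values that sit within the usual scatter of each other. Compound 2 alone stays a limit, not a number: the limit of > 52.4 uM in this assay, at which 1 of the 3 values shown sits.

The fluorine and the methoxy group of compound 3 enter together, so the compounds shown cannot separate them, and a plain 4-methoxyphenyl group would be needed to do so. As far as these compounds go, how an amine or a carboxylic acid on this aryl ring would read in this assay also remains open.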